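Swapping ethoxycarbonyl for aminomethyl on compound 2

The source may report more compounds than this note shows. Statements on the series, on what has been measured and on what is new or still open speak of the compounds shown alone.

- compound 1 `CN(C)C12CCNC(C(c3ccc(C(F)(F)F)cc3)C1)C(c1ccc(C(F)(F)F)cc1)C2` gives 9440 nM
- compound 2 `CCOC(=O)CN1CCC2(N3CCCCC3)CC(c3ccc(Cl)cc3)C1C(c1ccc(Cl)cc1)C2` gives 13100 nM
- compound 3 `NC(=O)CN1CCC2(N3CCCC3)CC(c3ccc(Cl)cc3)C1C(c1ccc(Cl)cc1)C2` gives 23900 nM

All three values come from an ADME assay on L6 cells (Rattus norvegicus) for cytotoxicity, read by resazurin assay, with a stated time of 72 h; on this read-out lower numbers stand for stronger inhibition and higher numbers for weaker inhibition. On these numbers, compound 2 at 13100 nM lies within the usual scatter of both compound 1 and compound 3, so neither comparison separates it from its neighbour.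

Compound 4 `NCCN1CCC2(N3CCCCC3)CC(c3ccc(Cl)cc3)C1C(c1ccc(Cl)cc1)C2` has not yet been measured. Its structure differs from that of compound 2 in one place: aminomethyl in place of ethoxycarbonyl on a saturated chain carbon bound to an amine nitrogen in a ring. In words, aminomethyl stands in place of ethoxycarbonyl on a saturated chain carbon bound to an amine nitrogen in a ring. Cut one bond further out, the same change reads (ethoxycarbonyl)methyl to 2-aminoethyl.

For the measured compounds named here, no two measured compounds differ in one place only, so no measured step shows how large such a change might be in this assay. The expectation therefore stays close to compound 2 at 13100 nM, with no step beyond the scatter. The expected change is a 1.3-fold lower number from compound 2 to compound 4 (0.12 log units; within the scatter). For compound 4 the estimated value is 10000 nM, with an expected range from 3500 nM to 30000 nM.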

Compound 4, half-maximal inhibitory concentration: 3370 nM
For compound 4 the middle estimate is 3.0-fold (0.47 log units) above the measured one; measured number below the stated range.
By their numbers in this assay, from the lowest: compound 4; then compounds 1, 2 and 3 (each within the scatter of the next, the first and the last beyond it).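

The saturated chain carbon bound to an amine nitrogen in a ring proves sensitive to what it carries: in this assay the change gives a 3.9-fold lower number from compound 2 to compound 4 (0.59 log units; beyond the scatter) and so stands beyond the usual scatter. For the compounds shown here, until now, no two measured compounds differed in one place only, so no step could show whether a change here matters at all. Aminomethyl in place of ethoxycarbonyl goes with modestly stronger inhibition on this read-out, and this single pair is the only support for that reading.

From the compounds shown here alone, it remains open whether the amine matters in itself or the departure of ethoxycarbonyl is enough, and whether a carboxylic acid or a longer chain ending in an amine would move the number further. Nothing measured here explains why the number falls.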